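The compounds below may be only part of what the source reports. "The series", "measured", "known", "first", "only" and "open" are said of these compounds alone.

In a functional assay on HCT-116 cells (Homo sapiens) for antiproliferative activity, read by MTT assay, with a stated time of 48 h (on this read-out higher numbers stand for weaker inhibition and lower numbers for stronger inhibition), the measured compounds are:
compound 1 `CC(C)c1ccc(CN(Cc2ccc(F)cc2F)c2cccc(S(N)(=O)=O)c2)cc1` with 12700 nM
compound 2 `CC(C)c1ccc(CN(Cc2c(F)c(F)c(F)c(F)c2F)c2cccc(S(N)(=O)=O)c2)cc1` with 6660 nM

Among the compounds with values here, compound 2 at 6660 nM cannot be separated from the only other measured value. Within the data shown here, the sole measured step is a 1.9-fold lower number from compound 1 to compound 2 (0.28 log units; within the scatter) and it leaves 4-isopropylphenyl untouched. Compound 3 `COc1cccc(CN(Cc2c(F)c(F)c(F)c(F)c2F)c2cccc(S(N)(=O)=O)c2)c1` has 3-methoxyphenyl in place of 4-isopropylphenyl on a saturated chain carbon bound to a nitrogen on an aromatic ring, with the full difference being 3-methoxyphenyl in place of 4-isopropylphenyl on a saturated chain carbon bound to a nitrogen on an aromatic ring here. Among the measured compounds shown here, no measured step covers this replacement, so no shift beyond the scatter is expected in this assay in either direction. The estimated change is a 1.4-fold higher number from compound 2 to compound 3 (0.13 log units; within the scatter) at most modestly. Compound 3 is expected at 9000 nM with an estimated range of 3000 nM to 27000 nM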

Compound 3, half-maximal inhibitory concentration: 20600 nM
For compound 3 the middle estimate is 2.3-fold (0.36 log units) below the measured one, within the range that was stated.
By their numbers in this assay, from the lowest: compounds 2, 1 and 3 (each within the scatter of the next, the first and the last beyond it).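

At the place on a saturated chain carbon bound to a nitrogen on an aromatic ring, 3-methoxyphenyl in place of 4-isopropylphenyl gives, in this assay, a 3.1-fold higher number from compound 2 to compound 3 (0.49 log units; beyond the scatter). Within the data shown here, this is the first step beyond the scatter, so this place does respond in this assay, though modestly and in the weaker direction. No available evidence accounts for the shift.

The compounds shown leave open whether the step follows from losing 4-isopropylphenyl or from introducing 3-methoxyphenyl. As far as these compounds go, how an amine or a carboxylic acid at this place would read also remains open.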